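The source may report more compounds than this note shows. Statements on the series, on what has been measured and on what is new or still open speak of the compounds shown alone.

Measured compounds:
Compound 1 `CC(=O)OC[C@H]1O[C@@H](CC(=O)/C=C/c2ccc([N+](=O)[O-])s2)[C@H](OC(C)=O)[C@@H](OC(C)=O)[C@@H]1OC(C)=O` gave "not determined" (no result reported) in an ADME assay on cells (Epithelial cell, Homo sapiens) for cytotoxicity, read by MTT assay, with a stated time of 24 h; a lower number here means that less compound is tolerated, a higher number that more compound is tolerated.
Compound 2 `CC(=O)OC[C@H]1O[C@@H](CC(=O)/C=C/c2cc(Cl)cc(Cl)c2)[C@H](OC(C)=O)[C@@H](OC(C)=O)[C@@H]1OC(C)=O` gave 32.9 nM in this assay.
Compound 3 `CC(=O)OC[C@H]1O[C@@H](CC(=O)/C=C/c2cccc3ccccc23)[C@H](OC(C)=O)[C@@H](OC(C)=O)[C@@H]1OC(C)=O` gave "not determined" (no result reported) in this assay.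

Compound 2 therefore stands alone: it holds the only number shown in this assay, while the two further entries carry no figure at all, so no comparison between measured compounds can be drawn and no step between them is known.

The next compound, compound 4 `CC(=O)OC[C@H]1O[C@@H](CC(=O)/C=C/c2ccc(C)cc2)[C@H](OC(C)=O)[C@@H](OC(C)=O)[C@@H]1OC(C)=O`, keeps the shared core of compound 2 and changes only the aryl group at the far end of the chain: 4-methylphenyl in place of 3,5-dichlorophenyl on a double-bonded chain carbon bound to a double-bonded chain carbon. Without any measured step to lean on, the size of this change cannot be read from the data, so the expectation rests on compound 2 alone with 32.9 nM as the anchor. The step from compound 2 to compound 4 is expected to be modest, a 1.5-fold higher number from compound 2 to compound 4 (0.18 log units; within the scatter), perhaps leaning toward a slightly higher number but possibly no more than the scatter. Compound 4 is therefore estimated at 50 nM, within a range from 15 nM to 200 nM.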

Compound 4, half-maximal cytotoxic concentration: 3.18 nM
The estimate for compound 4 lay 16-fold (1.20 log units) above the measured number; measured number outside the range, below it.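

Swapping in 4-methylphenyl in place of 3,5-dichlorophenyl on a double-bonded chain carbon bound to a double-bonded chain carbon gives, in this assay, a 10-fold lower number from compound 2 to compound 4 (1.01 log units; beyond the scatter), so the aryl group at this end of the chain can move the read-out well beyond the usual scatter while the shared core stays the same. Both groups are one six-membered aromatic ring of carbon only, with no hydrogen-bond donors or acceptors and no net charge, so the step comes with a change in what the ring carries, not in the ring itself. No measurement shown explains why the number falls.

This single step cannot separate losing the two chlorines from gaining the methyl, and compound 1 and compound 3 carry no number, so their steps cannot be read. On these data alone, whether a 4-chlorophenyl group or a phenyl ring bearing an amine would fall nearer compound 2 or compound 4 stays open.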